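The source may report more compounds than this note shows. Statements on the series, on what has been measured and on what is new or still open speak of the compounds shown alone.

Measured compounds in an assay on cells for displacement of a labelled ligand from adenosine receptor A1 (Homo sapiens), read by radioligand binding, with a stated time of 60 min, tested at 1 uM; a higher number here means more inhibition at the concentration tested (going by the name of the read-out), a lower number less inhibition:
compound 1, `CC1=C(C(=O)OC(C)C(F)(F)F)C(c2cccs2)NC(=O)N1`: 12%; 16% (2 entries)
compound 2, `CC1=C(C(=O)OC(C)C(F)(F)F)C(c2ccco2)NC(=O)N1`: 1%; 1% (2 entries)
compound 3, `CC1=C(C(=O)OCC(F)(F)F)C(c2ccsc2)NC(=O)N1`: 2%

Compound 3 stands on a single number in this assay, 2%; two further entries for compound 3 carry no number. Compound 3 and compound 2 lie within the scatter of each other; compound 1 gives 12%; 16% (2 entries) on repeated entries, with the values noted as the several entries of compound 1 in this assay, 12%; 16% (2 entries).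

Compound 4, `CC1=C(C(=O)OCC(F)(F)F)C(c2cccs2)NC(=O)N1`, is not yet measured. It differs from compound 3 by thiophen-2-yl in place of thiophen-3-yl on a saturated ring carbon. Going by the values given here, no step between measured compounds covers this change. The step from compound 3 to compound 4 is expected to be a number 6 percentage points higher from compound 3 to compound 4 (within the scatter), a small rise at most, possibly within the scatter, since compound 1 also carries thiophen-2-yl and gives 12%; 16% (2 entries). Compound 4 is therefore estimated at 8%, between 0% and 20%.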

Compound 4, a percentage reported as inhibition, at one concentration (the size of the read-out at that concentration, not a potency): 3%
Compound 4: middle estimate off by 5 percentage points, on the high side; the range from low to high includes it.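

Swapping the attachment point of the thiophene on the saturated ring carbon, thiophen-2-yl in place of thiophen-3-yl, gives a number 1 percentage points higher from compound 3 to compound 4 (within the scatter) in this assay, so this change has no readable effect with this ester. Compound 4 gives 3%, so thiophen-2-yl on this carbon does not by itself give the values of compound 1, which carries a different ester: the several entries of compound 1 in this assay, 12%; 16% (2 entries)

Open, on these data alone, is whether a phenyl ring or an amine at this carbon would shift the reading. Also open, as far as these compounds go, is how a carboxylic acid in place of the ester would read.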